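Replacing the 2,6-dimethylpiperidin-1-yl group of compound 2

The source may hold more compounds than are shown below. What is called first, only, known or untested is meant among the compounds shown, and "the series" means these compounds.

In an ADME assay on microsomes from liver (Rattus norvegicus) for metabolic stability, read by LC-MS, using NADPH, at 37 degrees C (on this read-out lower numbers stand for a shorter-lived compound and higher numbers for a longer-lived compound), compound 2 (`Cc1ccccc1-c1nc(CN2CCC(C(=O)NCCCN3[C@H](C)CCC[C@@H]3C)CC2)c(C)o1`) reads > 0.5 h as its half-life, and this is a limit of the assay and not a number. Compound 1 (`CC[C@@H]1C[C@H](CC)CN(CCCNC(=O)C2CCN(Cc3nc(-c4ccccc4C)oc3C)CC2)C1`) gives a measured 0.0917 h as its half-life. The next structure, compound 3 (`Cc1ccccc1-c1nc(CN2CCC(C(=O)NCCCN3CCCC(C(C)C)C3)CC2)c(C)o1`), keeps the rest of compound 2 and changes a single group: a group of 9 heavy atoms (8 carbon, 1 nitrogen; one six-membered non-aromatic ring with 1 hetero atom) in place of a group of 8 heavy atoms (7 carbon, 1 nitrogen; one six-membered non-aromatic ring with 1 hetero atom), on a saturated chain carbon, three bonds along the chain from an amide-type nitrogen and the group that enters has no common name.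

For the measured compounds named here, only one measured step bears on this change, made at the same place on a saturated chain carbon, three bonds along the chain from an amide-type nitrogen. Going by these compounds, the step of an at least 5.4-fold higher number from compound 1 to compound 2 (0.73 log units; beyond the scatter) lies beyond the scatter, and its full size stays open given the limit of > 0.5 h in this assay, at which 1 of the 2 values shown sits, as its upper end. Compound 3, like compound 1, lacks the 2,6-dimethylpiperidin-1-yl group, so it is expected to fall back towards compound 1 at 0.0917 h and to be the shorter-lived of the pair with compound 2. The expected change is an at least 3.1-fold lower number from compound 2 to compound 3 (0.49 log units; beyond the scatter) and would lie beyond the scatter. Compound 3 is estimated to give 0.16 h with a range from 0.07 h to 0.45 h as its half-life.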

Compound 3, half-life: 0.323 h
Beside the measured number, compound 3's estimate is 2.0-fold (0.31 log units) below it; the range from low to high includes it.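

In this assay, a six-membered ring group without the 2,6-dimethylpiperidin-1-yl pattern also stands clear of the 3,5-diethylpiperidin-1-yl group of compound 1 at this place on a saturated chain carbon, three bonds along the chain from an amide-type nitrogen: the read-out gives a 3.5-fold higher number from compound 1 to compound 3 (0.55 log units; beyond the scatter). The longer half-life seen for compound 2 therefore does not belong to the 2,6-dimethylpiperidin-1-yl group alone, since the group of 9 heavy atoms in compound 3 also moves the number well away from that of compound 1. The other step reads an at least 1.5-fold lower number from compound 2 to compound 3 (0.18 log units; that floor lies within the scatter), and as its floor lies within the scatter, the data do not firmly set compound 3 apart from compound 2, whose value is a limit and not a number: the limit of > 0.5 h in this assay, at which 1 of the 3 values shown sits.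

Going by these compounds, what stays open is the true size of the gap between compound 2 and compound 3, which would take a measured number for compound 2 in this assay. Also open, on these data alone, is how a plain piperidin-1-yl group or a morpholin-4-yl group would read at this place, and whether the same order would hold with a longer chain.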